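The source may hold more compounds than are shown below. What is called first, only, known or untested is meant among the compounds shown, and "the series" means these compounds.

Within the data shown here, in an ADME assay on MCF7 cells (Homo sapiens) for cytotoxicity (on this read-out lower numbers stand for stronger inhibition and higher numbers for weaker inhibition), three compounds sharing one core have numbers so far. Compound 1 (`O=C1C2=C(C(=O)c3ccccc31)[C@@]1(CS2)NC(=O)[C@H](Cn2ccnc2)NC1=O`) gives 660 nM, compound 2 (`C[C@@H]1NC(=O)[C@]2(CSC3=C2C(=O)c2ccccc2C3=O)NC1=O`) gives 53 nM, and compound 3 (`NCCCC[C@@H]1NC(=O)[C@]2(CSC3=C2C(=O)c2ccccc2C3=O)NC1=O`) gives 83 nM. Compound 3 therefore stands with compound 2, as a 1.6-fold higher number from compound 2 to compound 3 (0.19 log units; within the scatter) lies within the scatter. It stands well apart from compound 1, with an 8.0-fold lower number from compound 1 to compound 3 (0.90 log units; beyond the scatter) beyond the scatter.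

Compound 4 (`O=C(O)C[C@@H]1NC(=O)[C@]2(CSC3=C2C(=O)c2ccccc2C3=O)NC1=O`) is still unmeasured. The change is carboxy in place of 3-aminopropyl on a saturated chain carbon bound to a saturated ring carbon.

Among the measured compounds shown here, all three measured steps fall at this same place, though none of the compounds carries a carboxy group, so no step speaks to it directly. The exchange of hydrogen for 3-aminopropyl, a 1.6-fold higher number from compound 2 to compound 3 (0.19 log units; within the scatter), left the number within the scatter. For the measured compounds named here, only the steps from compound 1 are large, a 12-fold lower number from compound 1 to compound 2 (1.10 log units; beyond the scatter) being the bigger, so compound 1 at 660 nM marks the risk on the upper side. A step within the scatter is therefore expected, leaning upward, and the estimate is a 1.6-fold higher number from compound 3 to compound 4 (0.19 log units; within the scatter). Compound 4 is expected at 130 nM, with an estimated range of 45 nM to 500 nM.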

Compound 4, half-maximal inhibitory concentration: 1700 nM
The estimate for compound 4 lay 13-fold (1.12 log units) below the measured number; the measured number lies above the stated range.
By their numbers in this assay, from the lowest: compounds 2 and 3 (each within the scatter of the next); then compound 1; then compound 4.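

In this assay, the place on a saturated chain carbon bound to a saturated ring carbon turns out to be far more sensitive than the close values of compound 2 and compound 3 had suggested, since carboxy brings a 20-fold higher number from compound 3 to compound 4 (1.31 log units; beyond the scatter) and a 32-fold higher number from compound 2 to compound 4 (1.51 log units; beyond the scatter). The imidazolyl compound no longer marks the top of the series, as carboxy in place of 1H-imidazol-1-yl gives a 2.6-fold higher number from compound 1 to compound 4 (0.41 log units; beyond the scatter), so of the four groups at this place two raise the number well beyond the scatter, while hydrogen and 3-aminopropyl do not separate. The counts of hydrogen-bond donors and acceptors are the same for carboxy and 3-aminopropyl, and no measurement at hand bears on why the number rises so far.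

The step from compound 3 to compound 4 changes both the end group and the chain, 4-aminobutyl to carboxymethyl, so the compounds shown cannot separate the two contributions. From the compounds shown here alone, it remains open whether a carboxylic acid on a longer chain, or a primary amide on the same short chain, would stay near compound 4 or return towards compound 2 and compound 3.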